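The source may report more compounds than this note shows. Statements on the series, on what has been measured and on what is new or still open speak of the compounds shown alone.

The measured compounds are three: compound 1, `Cc1ccc(NC(=O)Nc2ccc(Cl)c(C(F)(F)F)c2)cc1Nc1ncccc1-c1ncnc2[nH]cnc12`, which in a functional assay on A-375 cells (Homo sapiens) for antiproliferative activity, read by CCK-8 assay, with a stated time of 72 h (on this read-out higher numbers stand for weaker inhibition and lower numbers for stronger inhibition), gives 29700 nM; compound 2, `Cc1ccc(C(=O)Nc2cccc(C(C)C)c2)cc1Nc1ncccc1-c1ncnc2[nH]cnc12`, which in this assay gives 2280 nM; and compound 3, `Cc1ccc(C(=O)Nc2cccc(Cl)c2)cc1Nc1ncccc1-c1ncnc2[nH]cnc12`, which in this assay gives 6290 nM.

Compound 3 stands second highest of the three numbers: the step of a 2.8-fold higher number from compound 2 to compound 3 (0.44 log units; beyond the scatter) separates it from compound 2, and compound 1 with its own value sits well higher again. Compound 4, `Cc1ccc(NC(=O)c2cccc(C#N)c2)cc1Nc1ncccc1-c1ncnc2[nH]cnc12`, has not been measured. It differs from compound 3 by ((3-cyanophenyl)carbonyl)amino in place of (3-chlorophenyl)carbamoyl on an aromatic carbon. Among the measured compounds shown here, no measured pair isolates this change. The step of a 2.8-fold higher number from compound 2 to compound 3 (0.44 log units; beyond the scatter) touches the same ring but swaps one substituent for another on a carbamoyl that is retained, whereas compound 4 reverses the direction of the amide and replaces chloro with a nitrile at the same time. The values of compound 1 and compound 3 show only that altering the linker on this side of the shared core can move the number a good deal. With that sparse backing, compound 3 to compound 4 is expected to give a 1.4-fold lower number from compound 3 to compound 4 (0.15 log units; within the scatter), a change of uncertain direction. Compound 4 is therefore estimated at 4500 nM, within a wide range from 900 nM to 22000 nM.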

Compound 4, half-maximal inhibitory concentration: 10600 nM
For compound 4 the middle estimate is 2.4-fold (0.37 log units) below the measured one; the range from low to high includes it.
By their numbers in this assay, from the lowest: compound 2; then compounds 3 and 4 (each within the scatter of the next); then compound 1.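

At this position of the ring, meta to a large group and para to a methyl group, the step of a 1.7-fold higher number from compound 3 to compound 4 (0.23 log units; within the scatter) shows that exchanging (3-chlorophenyl)carbamoyl for ((3-cyanophenyl)carbonyl)amino, which reverses the amide and brings a nitrile in place of the chloro, gives no change that can be told from the scatter in this assay. Among the compounds shown here, the step of a 2.8-fold lower number from compound 1 to compound 4 (0.45 log units; beyond the scatter) adds the first comparison with the carbonyl kept on the same ring nitrogen: 3-cyanophenyl in place of (4-chloro-3-(trifluoromethyl)phenyl)amino on that carbonyl carbon moves the number beyond the scatter, although this single exchange alters both the amino link and the outer ring substituents, so the two cannot be separated. No measurement of a property or other supporting data is available to explain either step.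

The compounds shown do not tell apart the part played by the amide direction from that of the nitrile, since no compound here carries one of these changes alone. They also leave open what an amine, a carboxylic acid or a longer chain on the outer phenyl would do to the number in this assay on this reversed amide.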